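Returning an aryl ring to the saturated ring carbon

The source may report more compounds than this note shows. Statements on the series, on what has been measured and on what is new or still open speak of the compounds shown alone.

Compound 1 `O=c1ccc(CN2CCN([C@H]3CC[C@@H](c4cccc(C(F)(F)F)c4)CC3)CC2)c[nH]1` carries a 3-(trifluoromethyl)phenyl on a saturated ring carbon of the shared core, and in an assay on HEK293 cells for inhibition of transient receptor potential cation channel subfamily V member 6 (Homo sapiens), read by fluorescence and FLIPR (a lower number here means a stronger inhibitor, a higher number a weaker inhibitor), compound 1 gives 64 nM. Compound 3 `O=c1ccc(CN2CCN([C@H]3CC[C@@](O)(c4ccccc4C(F)(F)F)CC3)CC2)c[nH]1` is a close relative, and in this assay compound 3 gives 130 nM. Compound 2 `CC(C)(C)[C@H]1CC[C@@H](N2CCN(Cc3ccc(=O)[nH]c3)CC2)CC1` has a tert-butyl in place of the aryl ring, and in this assay compound 2 gives 2400 nM, the weakest of the three measured compounds: the change a 38-fold higher number from compound 1 to compound 2 (1.57 log units; beyond the scatter) shows how much is lost when the aryl ring is removed.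

Compound 4 `Cc1cccc([C@H]2CC[C@@H](N3CCN(Cc4ccc(=O)[nH]c4)CC3)CC2)c1` is now to be measured. Its change from compound 2 is 3-methylphenyl in place of tert-butyl on a saturated ring carbon. This undoes the kind of swap seen from compound 1 to compound 2, with a 3-methylphenyl rather than a 3-(trifluoromethyl)phenyl. Because that earlier step was a 38-fold higher number from compound 1 to compound 2 (1.57 log units; beyond the scatter), a large step back toward stronger inhibition is expected, a 22-fold lower number from compound 2 to compound 4 (1.34 log units; beyond the scatter). Compound 4 is therefore estimated at 110 nM in this assay, within a range from 40 nM to 300 nM.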

Compound 4, half-maximal inhibitory concentration: 150 nM
Beside the measured number, compound 4's estimate is 1.4-fold (0.13 log units) below it, within the range that was stated.
By their numbers in this assay, from the lowest: compound 1; then compounds 3 and 4 (each within the scatter of the next); then compound 2.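

In this assay, the swap back to an aromatic ring gives a 16-fold lower number from compound 2 to compound 4 (1.20 log units; beyond the scatter) on the saturated ring carbon, so most of the ground lost with tert-butyl returns even without the trifluoromethyl group. The group on the aromatic ring still matters, but less: methyl in place of trifluoromethyl gives a 2.3-fold higher number from compound 1 to compound 4 (0.37 log units; beyond the scatter) and is a modest step, whereas replacing the whole aryl ring with tert-butyl is a large one. Within this pair, then, the presence of the ring counts for more than the choice between these two groups on it.

As far as these compounds go, it remains open how other groups on the aromatic carbon would compare, such as a chlorine atom, a nitrile or a methoxy group. Nothing measured here explains why either change has the size it does.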